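Fluorine on the Methylphenyl Ring of a Urea

This account rests on a few compounds, and the source may have more. Where it says the series, first, only, none or still open, it means among the compounds named here.

Measured so far in an ADME assay on the whole organism with Oryza sativa as the target, tested at 0.1 uM; on this read-out higher numbers stand for a weaker effect at the one concentration tested and lower numbers for a stronger effect:
- compound 1, `Cc1ccc(NC(=O)N[C@@H](C)c2ccccc2)cc1`, gives 100%
- compound 2, `CCCCCCCc1ccc(NC(=O)N[C@@H](C)c2ccccc2)cc1`, gives 100%
- compound 3, `C[C@H](NC(=O)Nc1ccc(F)cc1)c1ccccc1`, gives 96%

Compound 1 stands level with compound 2 at the top of the three numbers; its closest neighbour is compound 2, with no change at the digits printed from compound 1 to compound 2 (within the scatter), and its furthest is compound 3, with a number 4 percentage points lower from compound 1 to compound 3 (within the scatter), both within the scatter. The whole set therefore sits in a narrow band near the weak end of this assay.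

Compound 4, `Cc1ccc(NC(=O)N[C@@H](C)c2ccccc2)c(F)c1`, differs from compound 1 by fluoro in place of hydrogen on an aromatic carbon. The steps that come nearest to this are the exchanges on the same ring: a number 4 percentage points lower from compound 1 to compound 3 (within the scatter) and a number 4 percentage points lower from compound 2 to compound 3 (within the scatter). For the measured compounds named here, neither moved the number beyond the scatter, and no step among the measured compounds did. On that basis no change beyond the scatter is expected for compound 4, with a number 2 percentage points lower from compound 1 to compound 4 (within the scatter) as the expected step. The estimate for compound 4 in this assay is 98%, with a range from 88% to 100%.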

Compound 4, a percentage reported as activity, at one concentration (the size of the read-out at that concentration, not a potency): 100%
For compound 4 the middle estimate is 2 percentage points below the measured one; the range from low to high includes it.
By their numbers in this assay, from the lowest: compounds 3, 1, 2 and 4 (each within the scatter of the next).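

In this assay, fluoro in place of hydrogen on an aromatic carbon, ortho to a large group and meta to a methyl group, brings no change at the digits printed from compound 1 to compound 4 (within the scatter), so this step adds nothing to the read-out that can be told from the scatter. The earlier steps shown here only exchanged or lengthened the group at the methyl position of compound 1, whereas this one leaves that methyl in place and shows that a second ring position also accepts a fluoro with the number staying at the weak end of the assay. Nothing measured here bears on why the number holds.

On these data alone, whether an amine, a carboxylic acid or a longer chain at this same ring position would shift the number remains open. As far as these compounds go, all four compounds lie within the scatter of one another, so which change to the shared core could bring a clearly lower number also remains open.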